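Phenyl in place of propyl on the shared core

The compounds below may be only part of what the source reports. "The series", "measured", "known", "first", "only" and "open" are said of these compounds alone.

Measured so far:
compound 1 `CCCCc1ccc(-c2c(C)[nH]c(=O)n2Cc2ccccc2)cc1` — 12400 nM
compound 2 `CCCc1ccc(-c2c(C)[nH]c(=O)n2C)cc1` — 21500 nM
compound 3 `CCCCCCCCCCCOc1ccc(-c2c(C)[nH]c(=O)n2C)cc1` — 9700 nM

In a functional assay on brain (Rattus norvegicus, strain Wistar) for inhibition (on this read-out lower numbers stand for stronger inhibition and higher numbers for weaker inhibition), compound 2 gives the highest of the three numbers; its gap to compound 1 lies within the scatter, its gap to compound 3 just beyond it. Compound 4 `Cc1[nH]c(=O)n(C)c1-c1ccc(-c2ccccc2)cc1` is not yet measured. It differs from compound 2 in one place: phenyl in place of propyl on an aromatic carbon. For the measured compounds named here, no measured pair isolates this change, so the data show neither its size nor its direction. Compound 3 gives 9700 nM, a lower number than compound 2. Compound 1 gives 12400 nM, within the scatter of compound 2. On that basis a modest move toward lower numbers, possibly within the scatter, is expected, estimated as a 1.8-fold lower number from compound 2 to compound 4 (0.25 log units; within the scatter). Compound 4 is expected at 12000 nM, between 4000 nM and 40000 nM.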

Compound 4, half-maximal inhibitory concentration: 6300 nM
Compound 4: the middle estimate sits 1.9-fold (0.28 log units) above what was measured; low and high end bracket the measured number.
By their numbers in this assay, from the lowest: compounds 4, 3, 1 and 2 (each within the scatter of the next, the first and the last beyond it).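

In this assay, for the compounds shown here, phenyl in place of propyl on an aromatic carbon gives a 3.4-fold lower number from compound 2 to compound 4 (0.53 log units; beyond the scatter) and is the first measured pair to isolate a change at this position. The step shows that this aromatic carbon accepts a six-membered aromatic ring of carbon only, and that the number moves downward beyond the scatter with this exchange. Nothing available accounts for the step.

On these data alone, whether an amine or a carboxylic acid on the same aromatic carbon moves the number in the same direction stays open. So does the outcome with a pyridine ring in place of phenyl.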